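Working notes: bromo to hydrogen on the phenol ring

A few compounds are considered here, and "the series" means these few. Any claim that something is new, unique, unknown or untested is made for them only; others in the source may bear on it.

In a functional assay on SW480 cells (Homo sapiens) for cytotoxicity, read by sulforhodamine B assay, with a stated time of 48 h (on this read-out higher numbers stand for weaker inhibition and lower numbers for stronger inhibition), compound 1 `COc1ccc(/C=C/C(=O)c2ccc(N)c(-c3ccc(F)cc3)c2)cc1O` has no usable number, and its entry reads "not determined" (no result reported). Within the data shown here, compound 2 `COc1cc(/C=C/C(=O)c2ccc(N)c(-c3ccc(F)cc3)c2)cc(Br)c1O` gives 22900 nM, so it is the only compound with a measured value and cannot yet be ranked against any other. Compound 3 `COc1cc(/C=C/C(=O)c2ccc(N)c(-c3ccc(F)cc3)c2)ccc1O` is still to be measured. It differs from compound 2 at one place: hydrogen in place of bromo on an aromatic carbon, with hydrogen in place of bromo on an aromatic carbon, ortho to a hydroxy group and meta to a methoxy group. Among the measured compounds shown here, no measured pair shows what this change does in this assay, so no direction can be argued from the data. The expected 1.1-fold higher number from compound 2 to compound 3 (0.04 log units; within the scatter) is none beyond the usual scatter. Compound 3 is estimated at 25000 nM, with an expected range of 10000 nM to 60000 nM.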

Compound 3, half-maximal inhibitory concentration: 8350 nM
Beside the measured number, compound 3's estimate is 3.0-fold (0.48 log units) above it; measured number below the stated range.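

In this assay, among these compounds, this is the first measured pair, and hydrogen in place of bromo gives a 2.7-fold lower number from compound 2 to compound 3 (0.44 log units; beyond the scatter) on the shared core. The aromatic carbon ortho to a hydroxy group and meta to a methoxy group is therefore not indifferent to what it carries, and of these two compounds the one with bromo has the higher number. Among the compounds shown here, nothing measured so far accounts for this step, which stands as an observation only.

A single step does not show whether other groups at this carbon, such as chloro, methyl or an amine, would fall on the side of hydrogen or of bromo. Compound 1 gives "not determined" (no result reported) and offers no comparison with either neighbour.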